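Swapping methyl for fluoro on the pyridine of compound 3

This account rests on a few compounds, and the source may have more. Where it says the series, first, only, none or still open, it means among the compounds named here.

Measured compounds:
- compound 1, `c1cncc(-c2nc3ccccc3n2C2CC2)c1`, gives 49 nM in an assay on V79 cells for inhibition of cytochrome P450 11B2, mitochondrial (Homo sapiens), read by HTRF, with a stated time of 1 h; a lower number here means a stronger inhibitor, a higher number a weaker inhibitor
- compound 2, `Cc1ccncc1-c1nc2cc(F)c(F)cc2n1C1CC1`, gives 10.2 nM in this assay
- compound 3, `Cc1cncc(-c2nc3cc(F)c(F)cc3n2C2CC2)c1C`, gives 0.2 nM in this assay

Compound 3 has the lowest number of the three in this assay; compound 2 is its nearest neighbour and compound 1 lies furthest away, both separated from it by more than the usual scatter. The single step that joins two of these compounds in one place is a 51-fold lower number from compound 2 to compound 3 (1.71 log units; beyond the scatter), a large gain that came from putting a methyl onto an aromatic carbon.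

Compound 4, `Cc1c(F)cncc1-c1nc2cc(F)c(F)cc2n1C1CC1`, differs from compound 3 by fluoro in place of methyl on an aromatic carbon. The methyl that is removed here is not the one whose addition made the step from compound 2 to compound 3, so that step gives only an indirect pointer: it shows that this part of the structure is sensitive to small changes. Going by the values given here, no measured step shows what a fluoro does at this place. The expected outcome is therefore a modest loss, a 5.0-fold higher number from compound 3 to compound 4 (0.70 log units; beyond the scatter), with wide uncertainty. Compound 4 is estimated at 1 nM, within a range from 0.2 nM to 5 nM.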

Compound 4, half-maximal inhibitory concentration: 0.5 nM
For compound 4 the middle estimate is 2.0-fold (0.30 log units) above the measured one; measured number inside the range.
By their numbers in this assay, from the lowest: compound 3; then compound 4; then compound 2; then compound 1.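

Going by these compounds alone, compound 4 shows that a methyl is not the only small group that pays off at this place on the pyridine: the step of a 20-fold lower number from compound 2 to compound 4 (1.31 log units; beyond the scatter) is a large gain from a fluoro in place of hydrogen, of the same order as the gain a 51-fold lower number from compound 2 to compound 3 (1.71 log units; beyond the scatter) from a methyl in place of hydrogen. Exchanging one group for the other costs far less than either group gains over hydrogen, with a 2.5-fold higher number from compound 3 to compound 4 (0.40 log units; beyond the scatter) in this assay, a modest step though still beyond the scatter. So this place tolerates two different small groups, and compound 3 keeps a modest edge over compound 4, but nothing available explains why hydrogen does so much worse than either of them or why methyl edges out fluoro.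

Going by these compounds, what a chloro, a methoxy, a nitrile or a trifluoromethyl would do at this place stays open, so two groups cannot show whether the gain depends on size or on any other feature of the group. Compound 1 differs from the others in more than one place, so it cannot show how much the two fluoro groups on the core contribute to these low numbers.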